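From Methyl to Bromo on an Aromatic Carbon

This account rests on a few compounds, and the source may have more. Where it says the series, first, only, none or still open, it means among the compounds named here.

Compound 1 `CCc1ccc(NC(=O)C2Cc3cc(OC)c(OC)cc3C2=O)cc1` and compound 2 `COc1cc2c(cc1OC)C(=O)C(C(=O)Nc1ccccc1C)C2` have both been measured in a physicochemical assay for lipophilicity, read by mass spectrometry; a higher number here means a more lipophilic compound, a lower number a more polar compound. Within the data shown here, there compound 1 gives 3.11, while compound 2 gives 2.69, the lower of the two numbers so far. The next compound to be measured is compound 3 `COc1cc2c(cc1OC)C(=O)C(C(=O)Nc1ccccc1Br)C2`. It differs from compound 2 in one place, with bromo in place of methyl on an aromatic carbon, ortho to a large group (bromo in place of methyl on an aromatic carbon).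

Among the measured compounds shown here, only one measured step is available as a guide, and it is a loose one. With 2-methylphenyl in place of 4-ethylphenyl on an amide-type nitrogen, the result was a number 0.42 log units lower from compound 1 to compound 2 (beyond the scatter). For the measured compounds named here, that is a different swap, and no measured pair shows methyl exchanged for bromo. In this assay, a smaller, slightly upward change is therefore expected, one that may not clear the scatter. The expected step is a number 0.16 log units higher from compound 2 to compound 3 (within the scatter). The estimate for compound 3 is 2.85, with the measurement expected to fall between 2.5 and 3.2.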

Compound 3, partition coefficient: 3.03
The estimate for compound 3 lay 0.18 log units below the measured number; measured number inside the range.
By their numbers in this assay, from the lowest: compound 2; then compounds 3 and 1 (each within the scatter of the next).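

Among these compounds, this is the first measured change at this position alone. In this assay, bromo in place of methyl on an aromatic carbon, ortho to a large group, gives a number 0.34 log units higher from compound 2 to compound 3 (beyond the scatter) and so shows that exchanging one heavy atom for another, with no hydrogen-bond donor or acceptor entering or leaving, can shift the number by more than the scatter. The earlier step, a number 0.42 log units lower from compound 1 to compound 2 (beyond the scatter), separated 2-methylphenyl from 4-ethylphenyl, but a number 0.08 log units lower from compound 1 to compound 3 (within the scatter) leaves 2-bromophenyl and 4-ethylphenyl unresolved in this assay. Nothing measured here bears on the reason for either new step.

These compounds leave open how other groups at this position would compare, such as chloro, methoxy, an amine or a carboxylic acid on the same aromatic carbon. They also leave open whether bromo on another aromatic carbon of this ring would give a step of similar size.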